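This account rests on a few compounds, and the source may have more. Where it says the series, first, only, none or still open, it means among the compounds named here.

Measured in a functional assay on PC-3 cells (Homo sapiens) for antiproliferative activity; on this read-out higher numbers stand for weaker inhibition and lower numbers for stronger inhibition:
- compound 1 `Nc1nc(=O)n([C@H]2C=C[C@@H](CO)O2)cc1I`: > 100000 nM
- compound 2 `CC(=O)OC[C@@H]1C=C[C@H](n2cc(F)c(N)nc2=O)O1`: > 100000 nM
- compound 3 `CCCC(=O)OC[C@@H]1C=C[C@H](n2cc(F)c(N)nc2=O)O1`: > 100000 nM

Each of these three entries is a limit of the assay and not a number. Compound 3 therefore has no exact position in the series, and its entry of > 100000 nM is a limit. The same holds for the two other compounds, as the limit of > 100000 nM in this assay, at which 3 of the 3 values shown sit, records.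

The next compound is compound 4 `CCCCC(=O)OC[C@@H]1C=C[C@H](n2cc(F)c(N)nc2=O)O1`. Its difference from compound 3 is methyl in place of hydrogen on a saturated chain carbon, three bonds along the chain from a carbonyl carbon. Cut one bond further out, the same difference reads propyl to butyl.

Going by the values given here, one measured step bears on this change, and it is a step that the two limits leave unreadable from compound 2 to compound 3. That step involved ethyl in place of hydrogen on a saturated chain carbon bound to a carbonyl carbon, and it has no readable size. The expectation therefore rests mainly on (the limit of > 100000 nM in this assay, at which 3 of the 3 values shown sit), which gives no sign of a move in either direction in this assay. No change beyond the scatter is expected, and the expected step is a number no higher from compound 3 to compound 4 (the limit leaves the size open). Compound 4 is estimated at 100000 nM. For compound 4, the expected range runs from 30000 nM to 300000 nM.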

Compound 4, half-maximal inhibitory concentration: > 100000 nM
Compound 4: no number, only a limit (the forecaster's own chance of this, stated with the estimate: 85%); the middle value sits exactly at the limit.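

In this assay compound 4 gives > 100000 nM, which is a limit of the assay and not a number. The steps from compound 2 and from compound 3 to compound 4 therefore cannot be read. The compounds shown leave open whether lengthening the chain changes the activity at all, as all of them sit at one limit: the limit of > 100000 nM in this assay, at which 4 of the 4 values shown sit.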